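Swapping a Methyl for a Hydroxy in Compound 2

The source may hold more compounds than are shown below. What is called first, only, known or untested is meant among the compounds shown, and "the series" means these compounds.

Three related compounds have been tested so far in a functional assay (plasma) with Oryctolagus cuniculus as the target; a lower number here means a stronger inhibitor, a higher number a weaker inhibitor. Compound 1 `COC(=O)NC(CC(=O)N1CCC(n2c(C)nc3cnccc32)CC1)c1ccccc1` gives 1300 nM, compound 3 `COC/C(=C\C(=O)N1CCC(Cn2c(C)nc3cnccc32)CC1)c1ccccc1` gives 18 nM, and compound 2 `Cc1nc2cnccc2n1CC1CCN(C(=O)CC(C)(C)c2ccccc2)CC1` gives 6.7 nM. Compound 2 therefore has the lowest number of the three. Its gaps to both of the others lie beyond the usual scatter, which makes it the strongest inhibitor measured here.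

Compound 4 `Cc1nc2cnccc2n1CC1CCN(C(=O)CC(C)(O)c2ccccc2)CC1` has not yet been measured. It comes from compound 2 through a single structural change: hydroxy in place of methyl on a saturated chain carbon bound to an aromatic carbon and two saturated chain carbons. Put simply, a hydroxy stands in place of a methyl on a saturated chain carbon bound to an aromatic carbon and two saturated chain carbons.

Among the compounds with values here, no two measured compounds differ in just one place, so the data hold no direct guide to this swap. The expectation is therefore cautious, and it starts from compound 2 at 6.7 nM, the bottom of the numbers seen so far in this assay. The expected result is a moderate rise, meaning a weaker inhibitor, with an estimated change of a 4.5-fold higher number from compound 2 to compound 4 (0.65 log units; beyond the scatter). For compound 4 the estimated value is 30 nM, with an expected range from 8 nM to 120 nM.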

Compound 4, half-maximal inhibitory concentration: 6.9 nM
Beside the measured number, compound 4's estimate is 4.3-fold (0.64 log units) above it, and the stated range ends above it.
By their numbers in this assay, from the lowest: compounds 2 and 4 (each within the scatter of the next); then compound 3; then compound 1.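

Within the data shown here, this is the first pair that differs in only one place, so it gives the first direct reading of a single change, here at the saturated chain carbon bound to an aromatic carbon and two saturated chain carbons. In this assay, hydroxy in place of methyl gives a 1.0-fold higher number from compound 2 to compound 4 (0.01 log units; within the scatter), so the two numbers cannot be told apart, even though the hydroxy carries one hydrogen-bond donor and one hydrogen-bond acceptor and the methyl carries neither. No measurement shown here explains this match, so the result records what the number does and not why it does so.

What the compounds shown leave open is whether the same holds for other groups at this carbon, such as an amine, a methoxy, a fluorine or a longer chain like ethyl. Among these compounds, they also leave open whether the swap would read the same on a different side chain, such as the one in compound 3, since a single pair describes only this one setting and cannot support a general rule.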